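The source may hold more compounds than are shown below. What is called first, only, known or untested is meant among the compounds shown, and "the series" means these compounds.

Measured compounds:
compound 1, `O=C(NCCCCn1cccn1)c1cccc(C2SCC(=O)N2c2ccccn2)c1` — 60.3 nM
compound 2, `CCN(CC)c1ccc(N2C(=O)CSC2c2cccc(C(=O)NCCCCc3ccccc3)c2)cc1` — > 1000 nM
compound 3, `COc1ccccc1N1C(=O)CSC1c1cc(F)cc(C(=O)NCCCCc2ccccc2)c1` — 40.9 nM

Three compounds sharing the same core have been run in a functional assay on HOS-TE85 cells (Homo sapiens) for inhibition, read by CCK-8 assay, with a stated time of 72 h; a lower number here means a stronger inhibitor, a higher number a weaker inhibitor. Compound 1 gives 60.3 nM and compound 3 gives 40.9 nM; these two values lie within the usual scatter of each other, so no order between them can be read. Compound 2 stands apart: in this assay it returns only a limit, > 1000 nM, and no number. It is the one of the three that sits at the limit of > 1000 nM in this assay, at which 1 of the 3 values shown sits, so its true value is not known, only that it is weaker than that boundary.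

The next compound, compound 4, `CC(F)(F)c1cccc(N2C(=O)CSC2c2cccc(C(=O)NCCCCc3ccccc3)c2)c1`, is to be measured. It differs from compound 2 in one place: a group of 10 heavy atoms (8 carbon, 2 fluorine; one six-membered aromatic ring of carbon only) in place of a group of 11 heavy atoms (10 carbon, 1 nitrogen; one six-membered aromatic ring of carbon only), on an amide-type nitrogen in a ring. For the measured compounds named here, since compound 2 carries only a limit, no measured step of this kind exists and the size of the change cannot be taken from the data. It is expected that compound 4 will be a stronger inhibitor than the limit of compound 2 suggests, the step being estimated as an at least 5.0-fold lower number from compound 2 to compound 4 (0.69 log units; beyond the scatter). For compound 4 the value in this assay is expected to be about 200 nM, with a range from 50 nM to 1000 nM.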

Compound 4, half-maximal inhibitory concentration: 29.1 nM
Estimate against measurement, compound 4: 6.9-fold (0.84 log units) above; the whole stated range lies above it.
By their numbers in this assay, from the lowest: compounds 4, 3 and 1 (each within the scatter of the next, the first and the last beyond it). At a limit, above all of these: compound 2.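

In this assay, exchanging the 4-(diethylamino)phenyl on the amide-type nitrogen in the ring for the group of 10 heavy atoms (8 carbon, 2 fluorine) brings an at least 34-fold lower number from compound 2 to compound 4 (1.53 log units; beyond the scatter). For the compounds shown here, this gives the only measured step at this place, as no two earlier compounds differed in one place, and it shows that the group carried there can decide between a compound in the range of compound 1 and compound 3 and one that returns no number. The size of the step is a bound and not a measured distance, as compound 2 stands at a limit: the limit of > 1000 nM in this assay, at which 1 of the 4 values shown sits.

The compounds shown do not separate the loss of the diethylamino group from the arrival of the two fluorine atoms. An unsubstituted phenyl or a dimethylamino group at this place would bear on that question.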